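Hydroxy for chloro on the shared core: an expected step

A few compounds are considered here, and "the series" means these few. Any claim that something is new, unique, unknown or untested is made for them only; others in the source may bear on it.

Of the compounds shown here, three sharing one core have been measured in a functional assay on DLD-1 cells (Homo sapiens), read by microscopy and crystal violet staining, with a stated time of 20 h, tested at 10 ug/mL; a lower number here means less inhibition, a higher number more inhibition at the concentration tested (going by the name of the read-out). Compound 1 `O=C1NC(=S)S/C1=C\C=C\c1ccccc1` gives 81%. Compound 2 `O=C1NC(=S)S/C1=C\C=C\c1ccccc1OCc1ccncc1` gives 62%. Compound 3 `O=C1NC(=S)S/C1=C\C=C\c1ccccc1Cl` gives 80%. Compound 3 therefore stands second of the three, close to compound 1 and well clear of compound 2: the step of a number 1 percentage points lower from compound 1 to compound 3 (within the scatter) stays within the scatter, whereas a number 18 percentage points higher from compound 2 to compound 3 (beyond the scatter) lies beyond it.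

Compound 4 `O=C1NC(=S)S/C1=C\C=C\c1ccccc1O` has not been measured. It differs from compound 3 in one place: hydroxy in place of chloro on an aromatic carbon.

Two measured steps speak to this change. The substitution of chloro for hydrogen, a number 1 percentage points lower from compound 1 to compound 3 (within the scatter), changed nothing beyond the scatter, so the chlorine itself appears not to carry the activity. The only substituent that moved the read-out was the large (pyridin-4-yl)methoxy group, where a number 19 percentage points lower from compound 1 to compound 2 (beyond the scatter) was a modest loss. Hydroxy is one heavy atom, like chloro, not a large group, so the account expects a step of a number 6 percentage points lower from compound 3 to compound 4 (within the scatter) that is small, at most a slight loss, rather than a fall like that of compound 2. On that basis compound 4 is estimated at 74%, with a range from 55% to 88%.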

Compound 4, a percentage reported as inhibition, at one concentration (the size of the read-out at that concentration, not a potency): 65%
For compound 4 the middle estimate is 9 percentage points above the measured one; the measured number falls inside the stated range.
By their numbers in this assay, from the lowest: compounds 2 and 4 (each within the scatter of the next); then compounds 3 and 1 (each within the scatter of the next).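

Swapping one heavy atom for another at this place, on an aromatic carbon ortho to a large group, is enough to shift the read-out: the change gives a number 15 percentage points lower from compound 3 to compound 4 (beyond the scatter) even though chloro and hydroxy each count a single heavy atom, so small size alone does not keep a group neutral here. Set against hydrogen, hydroxy gives a number 16 percentage points lower from compound 1 to compound 4 (beyond the scatter) where chloro stayed within the scatter, which makes hydroxy the first small group in this set seen to move the number. Taking the (pyridin-4-yl)methyl off the oxygen gives a number 3 percentage points higher from compound 2 to compound 4 (within the scatter) and so recovers nothing that can be told from the scatter: among these four compounds, the two with an oxygen on this carbon read alike, as do the two without one.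

From the compounds shown here alone, whether that oxygen is what counts stays open, and a methoxy group, an amine or a fluoro group at the same place would bear on the question. Nothing available gives a measured reason for these steps.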